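A few compounds are considered here, and "the series" means these few. Any claim that something is new, unique, unknown or untested is made for them only; others in the source may bear on it.

Measured compounds in an ADME assay on PC-3 cells (Homo sapiens) for cytotoxicity, read by sulforhodamine B assay, with a stated time of 48 h, tested at 10 uM; a lower number here means less inhibition, a higher number more inhibition at the concentration tested (going by the name of the read-out):
compound 1 `CCCCc1cn(C(c2ccccc2)c2cc3cc(Br)ccc3nc2OC)nn1` gives 5.54%
compound 2 `CCOC(=O)c1cn(C(c2ccccc2)c2cc3cc(Br)ccc3nc2OC)nn1` gives 16.1%
compound 3 `COc1nc2ccc(Br)cc2cc1C(c1ccccc1)n1cc(CCCO)nn1` gives 14.7%

Compound 3 stands second highest of the three numbers. Its nearest neighbour is compound 2, and its furthest is compound 1, but the step of a number 1.4 percentage points lower from compound 2 to compound 3 (within the scatter) and the step of a number 9.2 percentage points higher from compound 1 to compound 3 (within the scatter) both lie within the scatter, so the three compounds cannot be ranked against one another on these numbers; all three sit in the low range of the read-out. Among the compounds with values here, only the step of a number 10.6 percentage points higher from compound 1 to compound 2 (beyond the scatter) went beyond the scatter, and it was modest.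

Compound 4 `COc1nc2ccc(Br)cc2cc1C(c1ccccc1)n1cc(CO)nn1` has not yet been measured in this assay. It differs from compound 3 in one place: hydroxy in place of 2-hydroxyethyl on a saturated chain carbon bound to an aromatic carbon. Within the data shown here, two measured steps bear on this change: a number 9.2 percentage points higher from compound 1 to compound 3 (within the scatter) and a number 1.4 percentage points lower from compound 2 to compound 3 (within the scatter). Both alter the same chain on the shared core. Neither moved the number beyond the scatter. Shortening the hydroxyalkyl chain is thus expected to leave the read-out essentially where compound 3 sits, with no step beyond the scatter in this assay. The step from compound 3 is estimated as a number 1.7 percentage points lower from compound 3 to compound 4 (within the scatter). Compound 4 is therefore expected to give about 13%, in a range from 2% to 25%.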

Compound 4, a percentage reported as inhibition, at one concentration (the size of the read-out at that concentration, not a potency): 4.65%
Beside the measured number, compound 4's estimate is 8.4 percentage points above it; measured number inside the range.
By their numbers in this assay, from the lowest: compounds 4, 1, 3 and 2 (each within the scatter of the next, the first and the last beyond it).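

In this assay, shortening 3-hydroxypropyl to hydroxymethyl gave a number 10.1 percentage points lower from compound 3 to compound 4 (beyond the scatter), so with the hydroxy group kept, the length of the chain on this aromatic carbon can move the number beyond the scatter, which none of the earlier steps to compound 3 had shown. Putting hydroxymethyl in place of ethoxycarbonyl gave a number 11.5 percentage points lower from compound 2 to compound 4 (beyond the scatter), whereas 3-hydroxypropyl in that same place had given a number 1.4 percentage points lower from compound 2 to compound 3 (within the scatter), so the two hydroxyalkyl chains do not behave alike against the ester. Replacing the propyl end of the butyl chain with hydroxy gave a number 0.9 percentage points lower from compound 1 to compound 4 (within the scatter), so a terminal hydroxy group does not by itself set compound 4 apart from compound 1, and all these modest steps remain in the low range of the read-out.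

No measured evidence is available to explain why the shorter chain gives this result. From the compounds shown here alone, two points stay open: whether the number would keep following chain length in a longer hydroxyalkyl chain, and whether an aminomethyl group or a carboxylic acid on this aromatic carbon would behave like hydroxymethyl or like ethoxycarbonyl.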